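Swapping Bromo for Iodo on a Second Core

The compounds below may be only part of what the source reports. "The series", "measured", "known", "first", "only" and "open" are said of these compounds alone.

Compound 1 `C=C(Br)C(=O)Nc1ccc(/C=C/C(=O)c2ccc(Br)cc2)cc1` was tested in a functional assay on HeLa cells (Homo sapiens) for antiproliferative activity, with a stated time of 48 h (on this read-out higher numbers stand for weaker inhibition and lower numbers for stronger inhibition), where compound 1 gives 1000 nM. Compound 2 `C=C(Br)C(=O)Nc1ccc(/C=C/C(=O)c2ccc(I)cc2)cc1` differs from it by iodo in place of bromo on an aromatic carbon, and in this assay compound 2 gives 7700 nM, a step of a 7.7-fold higher number from compound 1 to compound 2 (0.89 log units; beyond the scatter). Compound 3 `Nc1ccc(/C=C/C(=O)c2ccc(Br)cc2)cc1` keeps the bromo, but its core differs from the core of compound 1 by hydrogen in place of (1-bromoethenyl)carbonyl on a nitrogen on an aromatic ring; in this assay compound 3 gives 49000 nM, a step of a 49-fold higher number from compound 1 to compound 3 (1.69 log units; beyond the scatter). Compound 4 `Nc1ccc(/C=C/C(=O)c2ccc(I)cc2)cc1` has not yet been measured. Among the measured compounds shown here, it differs from compound 3 by iodo in place of bromo on an aromatic carbon, which is the same change, at the same place, as the one between compound 1 and compound 2, so this change occurs twice among the four compounds. Because that change produced a 7.7-fold higher number from compound 1 to compound 2 (0.89 log units; beyond the scatter), compound 4 is expected to show a step of similar size, a 4.1-fold higher number from compound 3 to compound 4 (0.61 log units; beyond the scatter). Compound 3 already gives 49000 nM in this assay, the highest number among the three measured compounds. Compound 4 is therefore estimated at 200000 nM, with a range from 60000 nM to 600000 nM.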

Compound 4, half-maximal inhibitory concentration: 58000 nM
Estimate against measurement, compound 4: 3.4-fold (0.54 log units) above; measured number below the stated range.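

In this assay, iodo in place of bromo on an aromatic carbon gives a 1.2-fold higher number from compound 3 to compound 4 (0.07 log units; within the scatter) on the core without the (1-bromoethenyl)carbonyl group, so the step seen on the other core did not carry over in size: the same change on two cores in this assay, a 7.7-fold higher number (0.89 log units; beyond the scatter) from compound 1 to compound 2 and a 1.2-fold higher number (0.07 log units; within the scatter) from compound 3 to compound 4, 6.5-fold (0.81 log units) apart, beyond the scatter of two such steps. Read the other way, hydrogen in place of (1-bromoethenyl)carbonyl on a nitrogen on an aromatic ring gives a 7.5-fold higher number from compound 2 to compound 4 (0.88 log units; beyond the scatter), a number that moves the same way as on the bromo pair but by a smaller step: the same change on two cores in this assay, a 49-fold higher number (1.69 log units; beyond the scatter) from compound 1 to compound 3 and a 7.5-fold higher number (0.88 log units; beyond the scatter) from compound 2 to compound 4, 6.5-fold (0.81 log units) apart, beyond the scatter of two such steps. These two comparisons rest on the same four compounds, so they show that the two changes do not act independently here, but they do not show why, nor which core is the more typical case.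

Only bromo and iodo are shown at the aromatic carbon, so it remains open how chloro, fluoro or a methoxy group would behave there on either core. On the nitrogen, only hydrogen and (1-bromoethenyl)carbonyl appear, which leaves open what an acetyl group would do to the size of the halogen step.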